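Bromo-to-hydrogen step carried across two related cores

The source may report more compounds than this note shows. Statements on the series, on what has been measured and on what is new or still open speak of the compounds shown alone.

Measured so far:
compound 1 `O=C1C(=O)N(CN2CCN(c3ccnc4cc(Cl)ccc34)CC2)c2cc(Br)ccc21` — 35800 nM
compound 2 `O=C1C(=O)N(CN2CCN(c3ccnc4cc(Cl)ccc34)CC2)c2ccccc21` — 37900 nM
compound 3 `NC(=S)N/N=C1/C(=O)N(CN2CCN(c3ccnc4cc(C(F)(F)F)ccc34)CC2)c2cc(Br)ccc21` — 39600 nM

Compound 1 and compound 2 share one core. In a functional assay on MDA-MB-468 cells (Homo sapiens) for cytotoxicity, read by sulforhodamine B assay, with a stated time of 48 h (a higher number here means a weaker inhibitor of growth, a lower number a stronger inhibitor of growth), compound 1 gives 35800 nM and compound 2 gives 37900 nM. The step between them, a 1.1-fold higher number from compound 1 to compound 2 (0.02 log units; within the scatter), comes from the change (hydrogen in place of bromo on an aromatic carbon); it stays within the scatter, so the two values are read as the same.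

Compound 3 stands on a second core. In this assay compound 3 gives 39600 nM, which sits within the scatter of both compound 1 and compound 2. How the core of compound 3 differs from the core of compound 1 is not broken down here.

Compound 4 `NC(=S)N/N=C1/C(=O)N(CN2CCN(c3ccnc4cc(C(F)(F)F)ccc34)CC2)c2ccccc21` has not yet been measured in this assay. It differs from compound 3 by hydrogen in place of bromo on an aromatic carbon, the same change that separates compound 1 from compound 2, at a place described in the same words. That earlier change produced no shift beyond the scatter. Because a 1.1-fold higher number from compound 1 to compound 2 (0.02 log units; within the scatter) was flat, the step of a 1.0-fold higher number from compound 3 to compound 4 (0.00 log units; within the scatter) is expected to be flat as well, with the second core treated as behaving like the first for this change. Among the measured compounds shown here, only one prior instance supports this, so the range is kept wide. For compound 4 the expected value in this assay is 40000 nM, estimated to fall between 18000 nM and 90000 nM.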

Compound 4, concentration for 50% growth inhibition: 10300 nM
Compound 4: middle estimate off by 3.9-fold (0.59 log units), on the high side; the whole stated range lies above it.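

In this assay, hydrogen in place of bromo on an aromatic carbon gives a 3.8-fold lower number from compound 3 to compound 4 (0.58 log units; beyond the scatter), so the flat result seen on the core of compound 1 does not carry over to the core of compound 3. For these two pairs, the outcome of the same change depends on the core that carries it: the same change on two cores in this assay, a 1.1-fold higher number (0.02 log units; within the scatter) from compound 1 to compound 2 and a 3.8-fold lower number (0.58 log units; beyond the scatter) from compound 3 to compound 4, 4.1-fold (0.61 log units) apart, beyond the scatter of two such steps

This rests on a single pair for each core and does not show which difference between the cores matters, whether the chloro against the trifluoromethyl, the carbonyl against the thiosemicarbazone, or the two together.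

Going by these compounds, it remains open whether the step on the core of compound 3 is specific to bromo, or whether another group at that place, such as fluoro, methoxy or an amine, would give a value nearer to that of compound 3 or of compound 4. Also open, on these data alone, is whether a compound combining the chloro with the thiosemicarbazone, or the trifluoromethyl with the carbonyl, would respond to the loss of bromo like the pair compound 1 and compound 2 or like the pair compound 3 and compound 4.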